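Swapping a phenyl for a 4-methylbenzyl on the sulfur

This account rests on a few compounds, and the source may have more. Where it says the series, first, only, none or still open, it means among the compounds named here.

Compound 1 `OC[C@H]1O[C@@H](n2cnc3c(NCc4ccco4)ncnc32)[C@H](O)[C@@H]1O` gives 36300 nM in an assay on isolated protein for binding affinity to Equilibrative nucleoside transporter 1 (Homo sapiens) (on this read-out higher numbers stand for weaker inhibition and lower numbers for stronger inhibition), and compound 2 `OC[C@H]1O[C@@H](n2cnc3c(Sc4ccccc4)ncnc32)[C@H](O)[C@@H]1O` gives 91200 nM, the higher of these two numbers; the step of a 2.5-fold higher number from compound 1 to compound 2 (0.40 log units; beyond the scatter) covers that gap. Compound 3 `Cc1ccc(CSc2ncnc3c2ncn3[C@@H]2O[C@H](CO)[C@@H](O)[C@H]2O)cc1` differs from compound 2 by 4-methylbenzyl in place of phenyl on a sulfur. For the measured compounds named here, no measured step tests this exchange on the sulfur; the single step from compound 1 to compound 2 swaps the whole group on the aromatic carbon. Compound 3 is therefore expected to move a 2.3-fold lower number from compound 2 to compound 3 (0.36 log units; beyond the scatter), a tentative estimate of 40000 nM within a wide range of 10000 nM to 150000 nM.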

Compound 3, half-maximal inhibitory concentration: 457 nM
Compound 3: the middle estimate sits 88-fold (1.94 log units) above what was measured; measured number outside the range, below it.
By their numbers in this assay, from the lowest: compound 3; then compound 1; then compound 2.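

The group on the sulfur matters far more than the earlier pair suggested: 4-methylbenzyl in place of phenyl gives a 200-fold lower number from compound 2 to compound 3 (2.30 log units; beyond the scatter) and so outweighs the earlier change of a 2.5-fold higher number from compound 1 to compound 2 (0.40 log units; beyond the scatter) by a wide margin. The same group also overtakes ((furan-2-yl)methyl)amino on the aromatic carbon, with a 79-fold lower number from compound 1 to compound 3 (1.90 log units; beyond the scatter) as the result. No evidence is available to explain this gain.

The exchange adds both a carbon link to the sulfur and a methyl on the ring, so the compounds shown cannot separate their contributions; plain benzyl on the sulfur would do so. From the compounds shown here alone, whether a chlorine in place of that methyl, or a longer chain between sulfur and ring, keeps the number this low also remains open.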